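This account rests on a few compounds, and the source may have more. Where it says the series, first, only, none or still open, it means among the compounds named here.

Within the data shown here, in a functional assay on A549 cells (Homo sapiens) for inhibition, read by sulforhodamine B assay, with a stated time of 48 h (a lower number here means a stronger inhibitor of growth, a higher number a weaker inhibitor of growth), compound 1 (`CC(C)c1cc(C(=O)N(C)c2ccc(NC(=O)CCCCCCCCC(=O)NO)cc2)c(O)cc1O`) gives 1080 nM, the only actual number available so far. Compound 2 (`CC(C)c1cc(C(=O)Nc2ccc(NC(=O)CCCCCCC(=O)NO)cc2)c(O)cc1O`) is reported only as a limit of the assay, > 10000 nM.

Compound 3 (`CC(C)c1cc(C(=O)N(C)c2ccc(NC(=O)CCCCCCCC(=O)NO)cc2)c(O)cc1O`) has not yet been measured. It differs from compound 1 by hydroxycarbamoyl in place of (hydroxycarbamoyl)methyl on a saturated chain carbon, seven bonds along the chain from a carbonyl carbon. Among the measured compounds shown here, no measured pair isolates this change, so the expectation rests on compound 1 and its value of 1080 nM. In this assay, the expected step of a 1.4-fold higher number from compound 1 to compound 3 (0.14 log units; within the scatter) is small, leaning slightly towards weaker growth inhibition but not beyond the usual scatter. The estimate for compound 3 is 1500 nM, with an expected range of 500 nM to 5000 nM.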

Compound 3, concentration for 50% growth inhibition: 440 nM
Estimate against measurement, compound 3: 3.4-fold (0.53 log units) above, and the stated range ends above it.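

The step shows that the length of the chain carrying this group matters in this assay: hydroxycarbamoyl in place of (hydroxycarbamoyl)methyl on a saturated chain carbon, seven bonds along the chain from a carbonyl carbon, gives a 2.5-fold lower number from compound 1 to compound 3 (0.39 log units; beyond the scatter), a modest gain in growth inhibition. Before this result only compound 1 had an actual number, so this is the first change that can be sized, and the two chain lengths are not equivalent. Compound 2 remains a limit of the assay and differs from compound 3 in more than one place, so it adds no step here: the limit of > 10000 nM in this assay, at which 1 of the 3 values shown sits.

A single step sets no trend, and the compounds shown leave open how a chain longer than that of compound 1 would behave. They also leave open whether a carboxylic acid in place of hydroxycarbamoyl would keep growth inhibition, and what the methyl on the amide nitrogen contributes on its own.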